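Urea-linked pyrazole series: dropping one trifluoromethyl

The source may hold more compounds than are shown below. What is called first, only, known or untested is meant among the compounds shown, and "the series" means these compounds.

Two members of the series have been measured so far. Compound 1 `O=C(Nc1cccc(-n2cc(-c3ccncc3)c(-c3cc(O)cc(Cl)c3)n2)c1)Nc1ccc(Cl)c(Cl)c1` gives 99% in a functional assay on M14 cells (Homo sapiens) for inhibition, read by sulforhodamine B assay, with a stated time of 48 h, tested at 0.01 uM (a lower number here means a stronger effect, a higher number a weaker effect of the compound at the concentration tested), and compound 2 `COc1cc(Cl)cc(-c2nn(-c3cccc(NC(=O)Nc4cc(C(F)(F)F)cc(C(F)(F)F)c4)c3)cc2-c2ccncc2)c1` gives 96% in this assay. The gap between compound 2 and compound 1 is within the usual scatter, so compound 2 sits alongside compound 1 and the two read-outs show essentially the same picture: at this concentration neither compound produces much of an effect.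

The next compound, compound 3 `COc1cc(Cl)cc(-c2nn(-c3cccc(NC(=O)Nc4cccc(C(F)(F)F)c4)c3)cc2-c2ccncc2)c1`, has not yet been measured. It differs from compound 2 in one place: hydrogen in place of trifluoromethyl on an aromatic carbon. Among the measured compounds shown here, no step between measured compounds is available to calibrate this change, so the expectation rests on the two numbers alone. Because compound 2 already gives 96%, little room remains for a higher read-out, and compound 3 is expected to stay near that level. The step from compound 2 to compound 3 is estimated at a number 1 percentage points higher from compound 2 to compound 3 (within the scatter), none beyond the scatter in either direction. For compound 3 the expected value in this assay is 97%, with a range from 85% to 105%.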

Compound 3, a percentage reported as activity, at one concentration (the size of the read-out at that concentration, not a potency): 98%
Beside the measured number, compound 3's estimate is 1 percentage points below it; low and high end bracket the measured number.
By their numbers in this assay, from the lowest: compounds 2, 3 and 1 (each within the scatter of the next).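

In this assay, among the compounds shown here, the first single-place step is a number 2 percentage points higher from compound 2 to compound 3 (within the scatter) and it comes with hydrogen in place of trifluoromethyl on an aromatic carbon. At this position, then, removing this trifluoromethyl group, with its four heavy atoms, leaves the read-out within the scatter, although both compounds sit where the effect at the tested concentration is small. No measured property in hand bears on this result.

A read-out this close to the weak end can show a loss of effect only poorly, so the step says little about whether this trifluoromethyl group would matter where a clear effect is seen. From the compounds shown here alone, whether an amine or a carboxylic acid on this aromatic carbon would move the read-out beyond the scatter remains open.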